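The compounds below may be only part of what the source reports. "The series", "measured", "known", "first", "only" and "open" are said of these compounds alone.

Three compounds in this series carry a measurement in a functional assay on HCT-116 cells (Homo sapiens) for inhibition, read by MTT assay, with a stated time of 48 h; on this read-out lower numbers stand for stronger inhibition and higher numbers for weaker inhibition. Compound 1, `C/C=C/C(=O)N(Cc1cc(OC)c(OC)c(OC)c1)c1ccc(OC)c(O)c1`, gives 8450 nM in this assay. Compound 2, `C=C(C)C(=O)N(Cc1ccc(OC)c(O)c1)c1cc(OC)c(OC)c(OC)c1`, gives 200 nM, and compound 3, `COc1ccc(CNc2cc(OC)c(OC)c(OC)c2)cc1`, gives 18400 nM. On these three numbers compound 1 stands second highest: compound 3 sits nearest to it with a number beyond the scatter above it, and compound 2 sits furthest with a number far below it. No two of these compounds differ in only one place, so none of these gaps can be tied to a single structural change.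

Compound 4, `COc1ccc(N(Cc2cc(OC)c(OC)c(OC)c2)C(=O)CCl)cc1O`, has not been measured. It differs from compound 1 in one place: chloromethyl in place of prop-1-en-1-yl on a carbonyl carbon. Among the compounds with values here, no measured pair shows this change, so its effect must be estimated without a direct precedent. Compound 4 is expected to give 4000 nM in this assay, within a range of 800 nM to 20000 nM. The expected step of a 2.1-fold lower number from compound 1 to compound 4 (0.32 log units; beyond the scatter) is a modest move toward a lower number, though a result within the scatter of compound 1 is also quite possible.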

Compound 4, half-maximal inhibitory concentration: 22500 nM
For compound 4 the middle estimate is 5.6-fold (0.75 log units) below the measured one; measured number outside the range, above it.
By their numbers in this assay, from the lowest: compound 2; then compound 1; then compounds 3 and 4 (each within the scatter of the next).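

The change at the carbonyl carbon gives the series its first comparison in one place: in this assay, chloromethyl in place of prop-1-en-1-yl gives a 2.7-fold higher number from compound 1 to compound 4 (0.43 log units; beyond the scatter) and so a modest step beyond the scatter toward weaker inhibition. The group on this carbonyl carbon, whose other neighbour is the amide-type nitrogen, can therefore move the number on its own while the rest of compound 1 stays the same. Nothing measured here explains the step or separates the loss of the double bond from the entry of chlorine.

This single pair leaves open whether a plain methyl, an unsubstituted ethenyl or a longer chain on the same carbonyl carbon would give a lower or a higher number. It also leaves open whether the same change would give a step of similar size on the core of compound 2.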